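From tert-Butyl to Phenyl: an Expected Small Step

The source may hold more compounds than are shown below. What is called first, only, known or untested is meant among the compounds shown, and "the series" means these compounds.

Of the compounds shown here, three sharing one core have been tested in an assay for inhibition of Amine oxidase [flavin-containing] A (Homo sapiens), read by fluorescence and spectrophotometry, using microsomes, with stated times of 30 min and 20 min; on this read-out higher numbers stand for weaker inhibition and lower numbers for stronger inhibition. Compound 1 `CC(C)(C)c1ccc(-c2noc(-c3ccc(C4=NCCN4)cc3)n2)cc1` gives 751 nM, the lower of the two values reported as numbers. Compound 2 `c1csc(-c2noc(-c3ccc(C4=NCCN4)cc3)n2)c1` gives 1570 nM, a difference from compound 1 that lies beyond the usual scatter. For compound 3 `O=c1c2ccccc2cnn1Cc1noc(-c2ccc(C3=NCCN3)cc2)n1` only a limit is reported, > 100000 nM, as noted in the limit of > 100000 nM in this assay, at which 1 of the 3 values shown sits. Compound 4 `c1ccc(-c2ccc(-c3noc(-c4ccc(C5=NCCN5)cc4)n3)cc2)cc1` has not been measured; it differs from compound 1 by phenyl in place of tert-butyl on an aromatic carbon. Within the data shown here, no measured pair shows this exact change, so the expectation rests on compound 1 alone. Both groups are made of carbon only and carry no charge. The step is therefore expected to be small, a 1.3-fold lower number from compound 1 to compound 4 (0.10 log units; within the scatter), within or near the scatter. Compound 4 is estimated at 600 nM, with a range from 200 nM to 2000 nM.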

Compound 4, half-maximal inhibitory concentration: > 100000 nM
Compound 4 was reported as a limit; the forecaster's own chance of this, stated with the estimate: 5%; at least 160-fold (2.22 log units) between middle value and limit.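

At this position, on an aromatic carbon para to a large group, two uncharged groups made only of carbon are not interchangeable: phenyl in place of tert-butyl gives an at least 130-fold higher number from compound 1 to compound 4 (2.12 log units; beyond the scatter). Compound 4 is reported only as a limit, not as a number, and it shares that limit with compound 3: the limit of > 100000 nM in this assay, at which 2 of the 4 values shown sit.

The compounds shown leave open which feature of phenyl matters, its ring or simply its larger size. A cyclohexyl group, a methoxy group or an amine at this place could begin to separate these.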